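Working notes: from compound 2 to compound 3

The source may report more compounds than this note shows. Statements on the series, on what has been measured and on what is new or still open speak of the compounds shown alone.

Measured in (a functional assay on HeLa cells (Homo sapiens) for inhibition, read by MTT assay, with a stated time of 72 h; a lower number here means a stronger inhibitor, a higher number a weaker inhibitor)
- compound 1 (`COc1cc(NC(C)CCCNC(=O)Nc2cccc(F)c2)c2ncccc2c1`), value (18000 nM)
- compound 2 (`COc1cc(NC(C)CCCNC(=O)NNC(=O)Nc2ccc(Cl)cc2)c2ncccc2c1`), value (120000 nM)

Compound 2 stands highest of the two measured numbers, making it the weaker inhibitor of the pair. Compound 3 (`COc1cc(NC(C)CCCNC(=O)Nc2ccc(F)cc2)c2ncccc2c1`) has not been measured. The structural change (4-fluorophenyl in place of ((4-chlorophenyl)carbamoyl)amino on an amide-type nitrogen) puts 4-fluorophenyl in place of ((4-chlorophenyl)carbamoyl)amino on an amide-type nitrogen. Among the measured compounds shown here, one measured step bears on it (a 6.7-fold higher number from compound 1 to compound 2 (0.82 log units; beyond the scatter)), a modest step that brought in the same ((4-chlorophenyl)carbamoyl)amino group in place of 3-fluorophenyl. For the measured compounds named here, no measured compound carries 4-fluorophenyl, so the comparison with 3-fluorophenyl remains untested. A step of similar size in the opposite direction is therefore expected (a 6.0-fold lower number from compound 2 to compound 3 (0.78 log units; beyond the scatter)), toward a lower number in (this assay). For compound 3 the estimated value is (20000 nM), with an expected range from (8000 nM) to (50000 nM).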

Compound 3, half-maximal inhibitory concentration: 20000 nM
Beside the measured number, compound 3's estimate shows no gap at the digits printed; low and high end bracket the measured number.
By their numbers in this assay, from the lowest: compounds 1 and 3 (each within the scatter of the next); then compound 2.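

In this assay, the step of a 6.0-fold lower number from compound 2 to compound 3 (0.78 log units; beyond the scatter) shows that the gap attached to ((4-chlorophenyl)carbamoyl)amino on the amide-type nitrogen is not tied to 3-fluorophenyl alone, since 4-fluorophenyl gives a gap of similar size. Among the compounds shown here, the step of a 1.1-fold higher number from compound 1 to compound 3 (0.05 log units; within the scatter) adds what the earlier compounds could not show: 3-fluorophenyl and 4-fluorophenyl cannot be told apart at this position in this read-out. No data on the compounds bear on why these steps take the sizes they do.

On these data alone, compound 2 brings in the carbamoylamino link and the chlorine together, so the part each plays remains open, and 4-chlorophenyl directly on the amide-type nitrogen would separate them. Also open, as far as these compounds go, is how far this position tolerates other groups, such as unsubstituted phenyl, a carboxylic acid on the phenyl ring, or a simple alkyl chain.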